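Furan regioisomers on two porcupine inhibitor cores

A few compounds are considered here, and "the series" means these few. Any claim that something is new, unique, unknown or untested is made for them only; others in the source may bear on it.

Compound 3 `O=C(CSc1nc2c(c(=O)n1-c1ccccc1)SCC2)Nc1ncc(-c2ccoc2)cn1` and compound 2 `O=C(CSc1nc2c(c(=O)n1-c1ccccc1)SCC2)Nc1ccc(-c2ccoc2)cn1` share the same amide side chain; how their two cores differ is not broken down here. In an assay on L cells for inhibition of Protein-serine O-palmitoleoyltransferase porcupine (Mus musculus), read by reporter gene assay, with a stated time of 24 h (on this read-out lower numbers stand for an effect already at smaller amounts and higher numbers for an effect only at larger amounts of compound), compound 3 gives 1.5 nM and compound 2 gives 1.5 nM, two values that lie within the scatter of each other. Compound 1 `O=C(CSc1nc2c(c(=O)n1-c1ccccc1)SCC2)Nc1ncc(-c2ccco2)cn1` carries furan-2-yl in place of furan-3-yl on an aromatic carbon and in this assay compound 1 gives 3.5 nM, so the step of a 2.3-fold higher number from compound 3 to compound 1 (0.37 log units; beyond the scatter). Compound 4 `O=C(CSc1nc2c(c(=O)n1-c1ccccc1)SCC2)Nc1ccc(-c2ccco2)cn1` carries the same kind of change from compound 2, (furan-2-yl in place of furan-3-yl on an aromatic carbon), although here the place is on a six-membered aromatic ring with 1 nitrogen, whereas in compound 1 it is on a six-membered aromatic ring with 2 nitrogen. Within the data shown here, only this one earlier step is available to lean on. A step of similar size is expected, a 2.3-fold higher number from compound 2 to compound 4 (0.37 log units; beyond the scatter), because a 2.3-fold higher number from compound 3 to compound 1 (0.37 log units; beyond the scatter) was beyond the scatter. Compound 4 is estimated at 3.5 nM in this assay, with a range from 1.5 nM to 8 nM.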

Compound 4, half-maximal effective concentration: 3.5 nM
The estimate for compound 4 equals the measured number at the digits printed, and the stated range covers the measured number.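

In this assay, furan-2-yl in place of furan-3-yl gives a 2.3-fold higher number from compound 2 to compound 4 (0.37 log units; beyond the scatter). The change therefore carries over between these two cores with the same size, whether the ring bearing it has one nitrogen or two: the same change on two cores in this assay, a 2.3-fold higher number (0.37 log units; beyond the scatter) from compound 3 to compound 1 and a 2.3-fold higher number (0.37 log units; beyond the scatter) from compound 2 to compound 4, 1.0-fold (0.00 log units) apart, within the scatter of two such steps. This rests on two matched pairs in a single assay, so it shows transfer only between these two cores and gives no reason for the step, nor any sign that it would hold on a third core.

Still open, from the compounds shown here alone, is whether an amine, a carboxylic acid or a longer chain such as n-butyl on that same aromatic carbon would behave alike on both cores. Also open, going by these compounds, is whether a thiophene ring would track either furan.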